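Dichloroacetanilides Against a Gastric Cancer Cell Line

A few compounds are considered here, and "the series" means these few. Any claim that something is new, unique, unknown or untested is made for them only; others in the source may bear on it.

Measured compounds:
- compound 1 `O=C(Nc1ccccc1)C(Cl)Cl`: "not determined" (no result reported)
- compound 2 `O=C(Nc1cccc(I)c1)C(Cl)Cl`: 58800 nM
- compound 3 `COc1cccc(NC(=O)C(Cl)Cl)c1`: 179000 nM

In a functional assay on BGC-823 cells (Homo sapiens) for antiproliferative activity, read by MTT assay, with a stated time of 72 h (a lower number here means a stronger inhibitor, a higher number a weaker inhibitor), compound 1 has no reported result. Compound 2 gives 58800 nM in this assay, and compound 3 gives 179000 nM. Compound 3 thus has the highest number of the two that exist, with compound 2 as its nearest neighbour; the step of a 3.0-fold higher number from compound 2 to compound 3 (0.48 log units; beyond the scatter) is the only one that can be compared here.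

Compound 4 `O=C(Nc1cccc(C(F)(F)F)c1)C(Cl)Cl` is the next entry. Relative to compound 3 the change is trifluoromethyl in place of methoxy on an aromatic carbon, meta to a group of 6 heavy atoms. Going by the values given here, the one measured step, a 3.0-fold higher number from compound 2 to compound 3 (0.48 log units; beyond the scatter), shows that replacing the methoxy by a different substituent at this position moved this assay by a modest amount. On that basis compound 4 is expected to land somewhere between the two measured values, and a step of a 2.2-fold lower number from compound 3 to compound 4 (0.35 log units; beyond the scatter) is estimated. Compound 4 is therefore expected to give about 80000 nM in this assay, within a range of 30000 nM to 250000 nM.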

Compound 4, half-maximal inhibitory concentration: 143000 nM
Compound 4: the middle estimate sits 1.8-fold (0.25 log units) below what was measured, and the stated range covers the measured number.
By their numbers in this assay, from the lowest: compound 2; then compounds 4 and 3 (each within the scatter of the next).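

In this assay, the exchange of methoxy for trifluoromethyl on this aromatic carbon gives a 1.3-fold lower number from compound 3 to compound 4 (0.10 log units; within the scatter), so a group with no hydrogen-bond acceptor and a group with one cannot be told apart here. Trifluoromethyl in place of iodo gives a 2.4-fold higher number from compound 2 to compound 4 (0.39 log units; beyond the scatter), which makes compound 2 the strongest of the three measured compounds, with its steps to both others beyond the scatter. No evidence is available to explain why iodo stands apart from the other two groups.

Steps from compound 1, whose entry reads "not determined" (no result reported), cannot be read, so how any of these substituents compares with the core of compound 1 remains open. Also open, going by these compounds, is whether an amine, a carboxylic acid or a longer alkyl chain at this position would stay with compound 2 or with compounds 3 and 4.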